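The source may report more compounds than this note shows. Statements on the series, on what has been measured and on what is new or still open speak of the compounds shown alone.

Within the data shown here, compound 2, `FC(F)(F)c1ccc(CSc2nc(Nc3cccc(C(F)(F)F)c3)c3ccccc3n2)cc1`, is one of two compounds measured in a functional assay on HGC-27 cells (Homo sapiens) for cytotoxicity, read by MTT assay, with a stated time of 72 h; a higher number here means a weaker inhibitor, a lower number a stronger inhibitor. Compound 2 gives 11700 nM, the lowest of the two numbers. The other is compound 1, `Cc1ccccc1Nc1nc(SCc2ccc(C(F)(F)F)cc2)nc2ccccc12`, which in this assay gives 27500 nM. Among the measured compounds shown here, the only measured step runs between these two: a 2.4-fold lower number from compound 1 to compound 2 (0.37 log units; beyond the scatter), a change at the nitrogen on the aromatic ring, where compound 2 carries the group that compound 3 now loses.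

Compound 3, `Fc1ccc(Nc2nc(SCc3ccc(C(F)(F)F)cc3)nc3ccccc23)cc1Cl`, differs from compound 2 in one place: 3-chloro-4-fluorophenyl in place of 3-(trifluoromethyl)phenyl on a nitrogen on an aromatic ring. For the measured compounds named here, the step from compound 1 to compound 2 is the one measured change at this position, and it was modest, so it shows that a swap of the aryl group here can move the number, though not by much. Going by the values given here, there is no measured step that involves 3-chloro-4-fluorophenyl itself, so the direction of the present change cannot be read from any pair; the expectation is of a step that stays close to the scatter, a 1.1-fold higher number from compound 2 to compound 3 (0.05 log units; within the scatter). Compound 3 is therefore estimated at 13000 nM, within a range from 5000 nM to 35000 nM.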

Compound 3, half-maximal inhibitory concentration: 14700 nM
Estimate against measurement, compound 3: 1.1-fold (0.05 log units) below, and the stated range covers the measured number.
By their numbers in this assay, from the lowest: compounds 2, 3 and 1 (each within the scatter of the next, the first and the last beyond it).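

In this assay, putting 3-chloro-4-fluorophenyl in place of 3-(trifluoromethyl)phenyl gives a 1.3-fold higher number from compound 2 to compound 3 (0.10 log units; within the scatter) and so does not separate these two aryl groups on the nitrogen, although the entering group has no trifluoromethyl and fewer heavy atoms than the one it replaces. The step from the 2-methylphenyl compound, a 1.9-fold lower number from compound 1 to compound 3 (0.27 log units; within the scatter) and thus also short of a clear difference, places compound 3 within reach of both other compounds, even though compound 1 and compound 2 themselves lie beyond the scatter of each other. Nothing measured here offers an explanation for these steps.

The three aryl groups therefore leave open whether the number at this nitrogen would move further with a group of another kind, such as a pyridine ring, a cyclohexyl ring or a longer chain, or with an amine or a carboxylic acid on the phenyl ring. All three compounds share everything away from this nitrogen, so they say nothing about how the number responds to a change elsewhere in the shared core.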